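The compounds below may be only part of what the source reports. "The series", "measured", "known", "first", "only" and "open" are said of these compounds alone.

Working notes on the series in a functional assay on Bel-7402 cells (Homo sapiens) for inhibition, read by MTT assay, with a stated time of 24 h, tested at 0.1 ug/mL; a higher number here means more inhibition of growth at the concentration tested, a lower number less inhibition of growth. Of the compounds shown here, three have numbers so far. Compound 1 (`CC(=O)SCCC(CCCCC(=O)O)SC(C)=O`) gives 10.3%, compound 2 (`O=C(O)CCCCC(CCSC(=O)c1ccccc1)SC(=O)c1ccccc1`) gives 1.09%, and compound 3 (`O=C(CCCCC1CCSS1)Nc1ccccc1Cl`) gives 6.83%. Compound 3 lies within the usual scatter of both compound 1 and compound 2, so its value does not separate from either.

The next compound is compound 4 (`O=C(CCCCC(S)CCS)Nc1ccccc1Cl`), which opens the ring of compound 3. The change is a group of 5 heavy atoms (3 carbon, 2 sulfur; no ring) in place of a group of 5 heavy atoms (3 carbon, 2 sulfur; one five-membered non-aromatic ring with 2 hetero atoms), on a saturated chain carbon, four bonds along the chain from a carbonyl carbon. The entering group is 1,3-disulfanylpropyl, and it has no ring.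

Within the data shown here, no measured pair differs in one place only, so the data give no direct guide to this change. The only hint is indirect: compound 1 has no ring and gives 10.3%, which is within the scatter of compound 3 at 6.83%. However, compound 1 also differs from compound 4 elsewhere, so this carries limited weight.

No step beyond the scatter is expected in this assay, and the estimated change is a number 2.2 percentage points higher from compound 3 to compound 4 (within the scatter). For compound 4 the expected value is 9%, with an estimated range of 1% to 22%.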

Compound 4, percent growth inhibition at one concentration: 5.11%
For compound 4 the middle estimate is 3.9 percentage points above the measured one, and the stated range covers the measured number.
By their numbers in this assay, from the lowest: compounds 2, 4, 3 and 1 (each within the scatter of the next).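

In this assay, among these compounds, opening the ring gives a number 1.7 percentage points lower from compound 3 to compound 4 (within the scatter) on a saturated chain carbon, four bonds along the chain from a carbonyl carbon, which is the first reading of a change in one place. At this position, replacing the five-membered ring with 2 hetero atoms by 1,3-disulfanylpropyl, with its 2 hydrogen-bond donors against 0 for the ring, does not separate the two compounds at the single concentration tested. Nothing available bears on the reason for this result.

Among the compounds shown here, the step covers only one exchange at one position in the compounds carrying the chlorophenyl amide, so it cannot be said whether the ring and the open form would also read alike at another concentration or with a different group on the amide nitrogen. Equally open, on these data alone, is whether a group of another kind at this chain carbon, such as an amine or a longer chain ending in a hydroxyl group, would give a step beyond the scatter.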